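A few compounds are considered here, and "the series" means these few. Any claim that something is new, unique, unknown or untested is made for them only; others in the source may bear on it.

Working notes on the series, read in a physicochemical assay, with a stated time of 30 min; on this read-out higher numbers stand for weaker inhibition and lower numbers for stronger inhibition. Compound 1 `COc1cc2c(cc1OC)C(=O)C(C(=O)Nc1ccccc1)C2` gives 61.3 ug/mL, compound 2 `COc1cc2c(cc1OC)C(=O)C(C(=O)Nc1ccc(Cl)cc1)C2` gives 56.8 ug/mL and compound 3 `COc1cc2c(cc1OC)C(=O)C(C(=O)Nc1ccc(Br)cc1)C2` gives 72.1 ug/mL. Compound 3 cannot be separated from the other two on these numbers: a 1.2-fold higher number from compound 1 to compound 3 (0.07 log units; within the scatter) and a 1.3-fold higher number from compound 2 to compound 3 (0.10 log units; within the scatter) both lie within the scatter.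

The next compound to be read is compound 4 `CCc1cccc(NC(=O)C2Cc3cc(OC)c(OC)cc3C2=O)c1`, with 3-ethylphenyl in place of 4-bromophenyl on an amide-type nitrogen.

All three measured steps bear on this change, since each alters the same aromatic ring on that nitrogen. Alongside the two above, a 1.1-fold lower number from compound 1 to compound 2 (0.03 log units; within the scatter) also lies within the scatter. Chloro and bromo have so far left the number in this assay unmoved beyond the scatter. Among the compounds with values here, no measured compound carries an ethyl group, however, and none carries a substituent at the ring position named in 3-ethylphenyl, so this change goes beyond what has been tested. No direction can be argued from the data, and no step beyond the scatter is expected.

The expected outcome is a 1.1-fold lower number from compound 3 to compound 4 (0.06 log units; within the scatter), an estimated step that stays within the scatter. For compound 4 the estimated value is 63 ug/mL, with an expected range of 35 ug/mL to 110 ug/mL.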

Compound 4, half-maximal inhibitory concentration: 64.1 ug/mL
For compound 4 the middle estimate is 1.0-fold (0.01 log units) below the measured one; measured number inside the range.
By their numbers in this assay, from the lowest: compounds 2, 1, 4 and 3 (each within the scatter of the next).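

In this assay, within the data shown here, the ethyl group, which no earlier compound carries, leaves compound 4 inseparable from the unsubstituted phenyl of compound 1 (a 1.0-fold higher number from compound 1 to compound 4 (0.02 log units; within the scatter)). Exchanging either halogenated ring for 3-ethylphenyl on the amide-type nitrogen also stays within the scatter (a 1.1-fold lower number from compound 3 to compound 4 (0.05 log units; within the scatter) for 4-bromophenyl and a 1.1-fold higher number from compound 2 to compound 4 (0.05 log units; within the scatter) for 4-chlorophenyl ), so the insensitivity seen with chloro and bromo now extends, across these four compounds, to an alkyl group and to the ring position named in 3-ethylphenyl. Nothing among the data shown accounts for this flat reading.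

Still open, on these data alone, is whether a group of another kind on this aromatic ring, such as an amine, a carboxylic acid or a longer chain, would carry the number beyond the scatter. Equally open, as far as these compounds go, is whether the reading would stay flat if a saturated ring replaced the aromatic ring on the amide-type nitrogen, or if a methyl group replaced the amide hydrogen.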